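The source may hold more compounds than are shown below. What is called first, only, known or untested is meant among the compounds shown, and "the series" means these compounds.

In a functional assay on the whole organism (strain Hartley) for inhibition, with Cavia porcellus as the target, with stated times of 15 min and 2 min (on this read-out higher numbers stand for an effect only at larger amounts of compound and lower numbers for an effect already at smaller amounts), compound 1 `CCCCC1([C@H](O)/C=C/C2[C@H](O)CC(=O)[C@@H]2C/C=C\CCCC(=O)O)CCC1` gives 0.00251 mg/kg and compound 2 `CCCC1([C@H](O)/C=C/C2[C@H](O)CC(=O)[C@@H]2C/C=C\CCCC(=O)O)CCC1` gives 0.003 mg/kg, two values within the scatter of each other. Compound 3 `CCCC1([C@@H](O)/C=C/C2[C@H](O)CC(=O)[C@@H]2C/C=C\CCCC(=O)O)CCC1` keeps the atoms and bonds of compound 2, but a stereocentre at a saturated chain carbon is drawn R in compound 2 and S in compound 3: the two compounds have the same atoms and bonds; at least one stereo element is drawn with a configuration in one of them and without one in the other: 1 of 6 stereo elements differ; a stereocentre at a saturated chain carbon is drawn R in compound 2 and S in compound 3. Within the data shown here, the only measured step, a 1.2-fold higher number from compound 1 to compound 2 (0.08 log units; within the scatter), is a chain change and sets no size for a stereocentre change. A clear move to a higher number in this assay is nevertheless expected, with wide uncertainty. The estimated value for compound 3 is 0.06 mg/kg, within 0.008 mg/kg to 0.5 mg/kg, an expected 20-fold higher number from compound 2 to compound 3 (1.30 log units; beyond the scatter).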

Compound 3, dose for half-maximal effect: 0.265 mg/kg
Beside the measured number, compound 3's estimate is 4.4-fold (0.65 log units) below it, within the range that was stated.
By their numbers in this assay, from the lowest: compounds 1 and 2 (each within the scatter of the next); then compound 3.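

In this assay, the change at this position gives an 88-fold higher number from compound 2 to compound 3 (1.95 log units; beyond the scatter), whereas the chain change gives a 1.2-fold higher number from compound 1 to compound 2 (0.08 log units; within the scatter). The configuration of this one stereocentre at a saturated chain carbon therefore moves the number beyond the scatter, with atoms and bonds unchanged. One caution applies to this reading: the fact that one of compounds 2 and 3 is drawn with a defined configuration and the other without, at the place where they differ

As far as these compounds go, whether the S configuration gives a step of similar size on the longer chain of compound 1 remains open. Also open, from the compounds shown here alone, is what a ketone at this carbon would give in place of either configuration.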